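The compounds below may be only part of what the source reports. "The series", "measured", "known", "first", "only" and "open" are said of these compounds alone.

Measured so far:
Compound 1, `CCCCCCCc1cn(C(c2ccccc2)c2cc3cc(Br)ccc3nc2OC)nn1`, gives 0.17%.
Compound 2, `COc1nc2ccc(Br)cc2cc1C(c1ccccc1)n1cc(-c2ccccc2)nn1`, gives 8.25%.

Both readings come from an ADME assay on HEK293 cells (Homo sapiens) for cytotoxicity, read by sulforhodamine B assay, with a stated time of 48 h, tested at 10 uM (a lower number here means less inhibition, a higher number more inhibition at the concentration tested (going by the name of the read-out)), and the two values stand within the scatter of each other: the step of a number 8.1 percentage points higher from compound 1 to compound 2 (within the scatter) is too small to separate the two compounds. Compound 2 is therefore not set apart from compound 1 on these numbers; its reading is simply the one nearer the top of a very narrow spread.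

Compound 3, `CCCCCCCCc1cn(C(c2ccccc2)c2cc3cc(Br)ccc3nc2OC)nn1`, has not yet been measured in this assay. It differs from compound 2 in a single place: octyl in place of phenyl on an aromatic carbon. Among the compounds with values here, the only step already measured, from compound 1 to compound 2, exchanged a heptyl chain for a phenyl ring on that same aromatic carbon and moved the reading by a number 8.1 percentage points higher from compound 1 to compound 2 (within the scatter), within the scatter. The change to compound 3 runs the other way, a ring leaving and an eight-carbon chain entering, so no step beyond the scatter is expected; if anything, a small drift back toward the value of compound 1 is expected, as a number 6.3 percentage points lower from compound 2 to compound 3 (within the scatter). Compound 3 is thus estimated at 2%, with a range from -6% to 12%.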

Compound 3, a percentage reported as inhibition, at one concentration (the size of the read-out at that concentration, not a potency): 14.6%
The estimate for compound 3 lay 12.6 percentage points below the measured number, outside the stated range (above it).
By their numbers in this assay, from the lowest: compounds 1, 2 and 3 (each within the scatter of the next, the first and the last beyond it).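

In this assay the exchange of phenyl for octyl on this aromatic carbon gives a number 6.4 percentage points higher from compound 2 to compound 3 (within the scatter) and so does not separate the ring from the chain at this position. Within the data shown here, the chain length does register: a methyl in place of hydrogen on a saturated chain carbon, seven bonds along the chain from an aromatic carbon, gives a number 14.4 percentage points higher from compound 1 to compound 3 (beyond the scatter) as the first step here to clear the usual scatter, though only a modest one. Nothing available explains this step.

From the compounds shown here alone, what remains open is whether this modest step marks the start of a trend or is a single difference between two neighbouring chains, since one step cannot establish a trend and a longer chain such as decyl would be needed to test it. It is also open how this position would respond to a group of a different kind, such as an amine or a carboxylic acid at the end of the chain, since every group shown here is built of carbon alone.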